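Trimethoxyphenyl pyrazolopyrimidines: swapping the aryl group

This account rests on a few compounds, and the source may have more. Where it says the series, first, only, none or still open, it means among the compounds named here.

Measured compounds:
compound 1, `COc1cc(-c2ccnc3cc(-c4ccc(Cl)cc4)nn23)cc(OC)c1OC`, 3340 nM
compound 2, `COc1ccc(-c2cc3nccc(-c4cc(OC)c(OC)c(OC)c4)n3n2)cc1[N+](=O)[O-]`, > 10000 nM
compound 3, `COc1cc(-c2cc3nccc(-c4c[nH]c5ccccc45)n3n2)cc(OC)c1OC`, > 10000 nM

Three compounds of the series have been run in a functional assay on HCT-116 cells (Homo sapiens) for inhibition, read by CCK-8 assay, with a stated time of 48 h; on this read-out lower numbers stand for stronger inhibition and higher numbers for weaker inhibition. Within the data shown here, compound 1 gives 3340 nM, and it is the only compound with a number. Compound 2 reaches only the limit of the assay, > 10000 nM. Compound 3 carries a 1H-indol-3-yl group on a core that is arranged differently from that of compound 1. Compound 3 likewise gives only a limit, > 10000 nM. So compound 1 stands alone with a measurable value, while (the limit of > 10000 nM in this assay, at which 2 of the 3 values shown sit).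

The next compound to be measured is compound 4, `COc1cc(-c2ccnc3cc(-c4c[nH]c5ccccc45)nn23)cc(OC)c1OC`. It differs from compound 1 in one place: 1H-indol-3-yl in place of 4-chlorophenyl on an aromatic carbon. Among the measured compounds shown here, no measured pair shows this change on this core, so its size cannot be read from the data. Given that compound 3, the other carrier of a 1H-indol-3-yl group, sits at the limit, the expectation is for weaker inhibition, with a step from compound 1 to compound 4 estimated at a 2.4-fold higher number from compound 1 to compound 4 (0.38 log units; beyond the scatter) in this assay. Compound 4 is thus expected to give about 8000 nM, within a range of 2500 nM to 25000 nM, and a real chance remains that only a limit is reported.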

Compound 4, half-maximal inhibitory concentration: 35 nM
Estimate against measurement, compound 4: 230-fold (2.36 log units) above, and the stated range ends above it.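

In this assay, among these compounds, the exchange of 4-chlorophenyl for 1H-indol-3-yl gives a 95-fold lower number from compound 1 to compound 4 (1.98 log units; beyond the scatter), the first step that can be read. The earlier compounds shown here offered one number and two limits, whereas this pair shows that the aromatic carbon of the five-membered aromatic ring with 2 nitrogen is a site where the choice of aromatic group strongly changes inhibition on the shared core. The entering group brings 1 hydrogen-bond donor and a five-membered aromatic ring that 4-chlorophenyl lacks, but nothing available explains the size of the step.

Compound 3 also carries 1H-indol-3-yl but gives only a limit of the assay, > 10000 nM, and since its core is arranged differently, it cannot show what that arrangement contributes. Going by these compounds, it also remains open whether the result depends on the indole nitrogen-bound hydrogen or on the fused ring system, a question that 1-methylindol-3-yl or 2-naphthyl on the core of compound 1 would help to separate.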